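Chloro for hydrogen on a benzyl group: expected cytotoxicity

The source may hold more compounds than are shown below. What is called first, only, known or untested is meant among the compounds shown, and "the series" means these compounds.

Compound 1 `CCOC(=O)C1=C(C(=O)OCC)C2CSC(CS1)N2CCCC(=O)OCc1c(-c2ccccc2)no[n+]1[O-]`: > 200000 nM
Compound 2 `CCOC(=O)C1=C(C(=O)OCC)C2CSC(CS1)N2Cc1ccccc1`: 200000 nM
Compound 3 `COC(=O)C1=C(C(=O)c2ccc(Cl)cc2)C2CSC(CS1)N2Cc1ccc(OC)cc1`: 9700 nM

All three compounds share a core and were tested in an ADME assay on J774 cells (Mus musculus) for cytotoxicity, read by WST assay, with a stated time of 24 h; a higher number here means that more compound is needed for the effect, a lower number that less compound is needed. For compound 1 the result is a limit of the assay rather than a number, which is the limit of > 200000 nM in this assay, at which 1 of the 3 values shown sits. Of the two real numbers, compound 2 holds the higher one, so it needs more compound for the effect than compound 3, and that gap is beyond the usual scatter. Compound 3, however, differs from compound 2 at several places at once, so no single change can be read from that pair.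

Compound 4 `CCOC(=O)C1=C(C(=O)OCC)C2CSC(CS1)N2Cc1ccc(Cl)cc1` has not yet been measured in this assay. It differs from compound 2 in one place only: chloro in place of hydrogen on an aromatic carbon. Within the data shown here, no measured pair shows what this change does on its own, so the expected step is small, a 1.3-fold lower number from compound 2 to compound 4 (0.12 log units; within the scatter), with no direction beyond the scatter. Compound 4 is therefore expected to give about 150000 nM, with a likely range from 60000 nM to 300000 nM.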

Compound 4, half-maximal effective concentration: > 200000 nM
Compound 4 ended at the assay's limit; the forecaster's own chance of this, stated with the estimate: 30%; middle value at least 1.3-fold (0.12 log units) away from the limit.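

In this assay, among these compounds, the change from benzyl to 4-chlorobenzyl can now be read directly for the first time, as a number no lower from compound 2 to compound 4 (the limit leaves the size open). Chloro in place of hydrogen at this aromatic carbon, para to a large group, therefore brings no lower number here, so the ring tolerates this change without any added effect in this assay. How far the number rises, if it rises at all, cannot be read, since the result ends at the top of what the assay reports: the limit of > 200000 nM in this assay, at which 2 of the 4 values shown sit.

The compounds shown leave open whether an amine or a carboxylic acid in place of the chloro would give a lower number. They also leave open what the same chloro change does on a compound whose number sits well below the limit.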